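Swapping the Pyrrolidine Amine for a Diaminocyclohexane

This account rests on a few compounds, and the source may have more. Where it says the series, first, only, none or still open, it means among the compounds named here.

Compound 1 `CN(C)[C@H]1CCN(c2cccc3c2C[C@H](CN(C)[C@H]2CCCc4cccnc42)NC3)C1` is one of two compounds measured in a functional assay on CCRF-CEM cells for antagonist activity at C-X-C chemokine receptor type 4 (Homo sapiens), read by calcium flux, with stated times of 25 min and 90 s (on this read-out lower numbers stand for stronger inhibition and higher numbers for weaker inhibition), and in this assay compound 1 gives 10.9 nM, the lowest of the two numbers shown, though not separated from its neighbour. Compound 2 `CN1CC[C@H]2CN(c3cccc4c3C[C@H](CN(C)[C@H]3CCCc5cccnc53)NC4)C[C@H]21`, which carries a fused bicyclic amine at the same aromatic carbon, gives in this assay 11.4 nM. For the measured compounds named here, the only measured step at that position is a 1.0-fold higher number from compound 1 to compound 2 (0.02 log units; within the scatter), so the two amine substituents examined so far cannot be told apart.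

Compound 3 `CN(C[C@H]1Cc2c(cccc2N[C@H]2CC[C@H](N)CC2)CN1)[C@H]1CCCc2cccnc21` has not been measured in this assay. It differs from compound 1 by (4-aminocyclohexyl)amino in place of 3-(dimethylamino)pyrrolidin-1-yl on an aromatic carbon. Going by the values given here, the step from compound 1 to compound 2 is the only one that bears on this change, and it was flat; that step exchanged one ring amine for another, whereas compound 3 brings in two hydrogen-bond donors and a six-membered ring of carbon only, which no measured pair covers. Compound 3 is therefore expected to sit close to compound 1, with a step of a 1.4-fold higher number from compound 1 to compound 3 (0.14 log units; within the scatter) and a wider uncertainty than the scatter alone. The estimate for compound 3 in this assay is 15 nM, within a range from 4 nM to 60 nM.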

Compound 3, half-maximal inhibitory concentration: 755 nM
For compound 3 the middle estimate is 50-fold (1.70 log units) below the measured one; measured number above the stated range.
By their numbers in this assay, from the lowest: compounds 1 and 2 (each within the scatter of the next); then compound 3.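

In this assay, for the compounds shown here, the aromatic carbon that seemed indifferent while only two ring amines were compared proves highly sensitive to the group it carries. Placing (4-aminocyclohexyl)amino there gives a 69-fold higher number from compound 1 to compound 3 (1.84 log units; beyond the scatter) and, against the fused bicyclic amine, a 66-fold higher number from compound 2 to compound 3 (1.82 log units; beyond the scatter) as the second large step. The group that enters holds the same atoms as 3-(dimethylamino)pyrrolidin-1-yl, joined differently, so atom content alone does not set the number at this position. No evidence is available that accounts for this loss.

The change alters several features at once, replacing a five-membered ring containing nitrogen with a six-membered ring of carbon only and introducing hydrogen-bond donors, and the compounds shown do not separate these features. A 3-aminopyrrolidin-1-yl group, which keeps the five-membered ring but carries a primary amine, or a [4-(dimethylamino)cyclohexyl]amino group, which keeps the carbon-only ring but has a tertiary amine at its far end, could show which of the features goes with the large step.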